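Replacing acetamido with hydroxy: working notes

The source may hold more compounds than are shown below. What is called first, only, known or untested is meant among the compounds shown, and "the series" means these compounds.

Measured in a functional assay for inhibition, with Homo sapiens as the target; a lower number here means a stronger inhibitor, a higher number a weaker inhibitor:
- compound 1 `NS(=O)(=O)c1ccc(Nc2nccc(-c3cccnc3)n2)cc1`: 200 nM
- compound 2 `CC(=O)Nc1ccc(Nc2nccc(-c3cccnc3)n2)cc1`: 3600 nM
- compound 3 `CC(=O)Nc1ccc(Nc2nccc(-c3ccccn3)n2)cc1`: 1500 nM

Of the three measured compounds, compound 2 has the highest number in this assay, at 3600 nM, making it the weakest inhibitor so far. The next compound is compound 4 `Oc1ccc(Nc2nccc(-c3cccnc3)n2)cc1`, which carries hydroxy in place of acetamido on an aromatic carbon.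

For the measured compounds named here, only one measured step changes the group at this place: an 18-fold higher number from compound 1 to compound 2 (1.26 log units; beyond the scatter). Going by the values given here, this large step shows that acetamido gives a much higher number than sulfamoyl, but it says nothing directly about hydroxy, which no measured compound carries. The modest step of a 2.4-fold lower number from compound 2 to compound 3 (0.38 log units; beyond the scatter) concerns the pyridinyl group and bears on this change only weakly.

Losing acetamido is therefore expected to lower the number, though by less than the sulfamoyl comparison, and the uncertainty is wide. The expected change is a 2.4-fold lower number from compound 2 to compound 4 (0.38 log units; beyond the scatter). Compound 4 is estimated at 1500 nM, with an expected range of 350 nM to 6000 nM.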

Compound 4, half-maximal inhibitory concentration: 5100 nM
Compound 4: middle estimate off by 3.4-fold (0.53 log units), on the low side, and the stated range covers the measured number.
By their numbers in this assay, from the lowest: compound 1; then compound 3; then compounds 2 and 4 (each within the scatter of the next).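

In this assay, cutting acetamido down to hydroxy, on an aromatic carbon para to a large group, leaves the number within the scatter (a 1.4-fold higher number from compound 2 to compound 4 (0.15 log units; within the scatter)), so these two groups are not separated here despite the loss of most of the substituent's heavy atoms. Sulfamoyl stands apart from hydroxy as it does from acetamido (a 26-fold higher number from compound 1 to compound 4 (1.41 log units; beyond the scatter); an 18-fold higher number from compound 1 to compound 2 (1.26 log units; beyond the scatter)), so among these three groups, with pyridin-3-yl held constant, only sulfamoyl gives a clearly lower number. Nothing at hand accounts for the gap between sulfamoyl and the other two groups.

As far as these compounds go, it remains open whether a carboxylic acid, a methanesulfonyl group or an amine at this place would approach sulfamoyl or stay with hydroxy and acetamido. Also open, from the compounds shown here alone, is whether the pyridin-2-yl change carries over to the sulfamoyl and hydroxy compounds.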